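A few compounds are considered here, and "the series" means these few. Any claim that something is new, unique, unknown or untested is made for them only; others in the source may bear on it.

Compound 1 `COc1ccc(CN2C(=O)C(=O)c3cc(-c4ccc(OC)cc4)ccc32)cc1` stands lowest of the two numbers in a functional assay on K562 cells (Homo sapiens) for antiproliferative activity, read by MTT assay, with a stated time of 48 h (on this read-out higher numbers stand for weaker inhibition and lower numbers for stronger inhibition), at 30 nM. Among the measured compounds shown here, compound 2 `COc1ccc(-c2ccc3c(c2)C(=O)C(=O)N3Cc2cccc(OC)c2)cc1` gives 680 nM in this assay, and a 23-fold higher number from compound 1 to compound 2 (1.36 log units; beyond the scatter) is the only measured step. Compound 3 `COc1ccc(CN2C(=O)C(=O)c3cc(-c4cccc(OC)c4)ccc32)cc1` differs from compound 1 by 3-methoxyphenyl in place of 4-methoxyphenyl on an aromatic carbon. The measured step moved the methoxy on the 4-methoxyphenyl on a saturated chain carbon bound to an amide-type nitrogen in a ring, not on the aromatic carbon of the fused system changed here, so it is only a weak guide. A step of a 3.0-fold higher number from compound 1 to compound 3 (0.48 log units; beyond the scatter) towards a higher number is expected, smaller than the measured one. Compound 3 is estimated at 90 nM, with a range of 25 nM to 400 nM.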

Compound 3, half-maximal inhibitory concentration: 100 nM
For compound 3 the middle estimate is 1.1-fold (0.05 log units) below the measured one, and the stated range covers the measured number.
By their numbers in this assay, from the lowest: compound 1; then compound 3; then compound 2.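

In this assay, the 4-methoxyphenyl on the aromatic carbon also counts: 3-methoxyphenyl there gives a 3.3-fold higher number from compound 1 to compound 3 (0.52 log units; beyond the scatter), so the preference for 4-methoxyphenyl now appears at both sites of the series. This step is smaller than a 23-fold higher number from compound 1 to compound 2 (1.36 log units; beyond the scatter), and the site on the saturated chain carbon is the more sensitive of the two in these compounds. No measurement here accounts for either step.

Open, going by these compounds, is how a carboxylic acid or a dimethylamino group would fare in place of the methoxy on this aromatic ring. Also open, on these data alone, is whether the two 3-methoxyphenyl changes would add up in a single compound.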